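The source may report more compounds than this note shows. Statements on the series, on what has been measured and on what is new or still open speak of the compounds shown alone.

Three compounds built on one shared core were examined in an ADME assay on Vero cells (Chlorocebus sabaeus) for cytotoxicity, read by MTT assay, with a stated time of 72 h; on this read-out higher numbers stand for lower toxicity in this test and lower numbers for higher toxicity in this test. Compound 1 `CC(=O)NCCSCC(=O)c1c(C)[n+]([O-])c2ccccc2[n+]1[O-]` returned "not determined" (no result reported) in this assay . Compound 2 `Cc1c(C(=O)CSCCNC(=O)c2ccccc2)[n+]([O-])c2ccccc2[n+]1[O-]` reached only a limit of the assay, being reported as > 100 ug/mL in this assay . Compound 3 `Cc1c(C(=O)CSCCNC(=O)C2CCCCC2)[n+]([O-])c2ccccc2[n+]1[O-]` likewise returned "not determined" (no result reported) in this assay . So compound 3 has no number of its own to stand on: one companion sits at a limit, the other has no entry, and the limit of > 100 ug/mL in this assay, at which 1 of the 3 values shown sits, is the only evidence in hand. Compound 4 `Cc1c(C(=O)CSCCNC(=O)c2ccncc2)[n+]([O-])c2ccccc2[n+]1[O-]` differs from compound 3 by pyridin-4-yl in place of cyclohexyl on a carbonyl carbon. No measured step exists between any two of these compounds, so no size or direction of change in this assay can be drawn from the data, and for compound 4 no shift beyond the scatter is expected. Compound 4 is therefore expected to give about 100 ug/mL in this assay, in the range 40 ug/mL to 200 ug/mL, and most likely to come back as a limit only.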

Compound 4, half-maximal cytotoxic concentration: 50 ug/mL
Compound 4: middle estimate off by 2.0-fold (0.30 log units), on the high side, and the stated range covers the measured number.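

In this assay, within the data shown here, compound 4 gives 50 ug/mL, the first value in this set that is a number and not a limit, so this position can carry a group that brings the read-out into the measurable range. Compound 2 stands at a limit of the assay, > 100 ug/mL. The change to pyridin-4-yl on a carbonyl carbon reads as an at least 2.0-fold lower number from compound 2 to compound 4 (0.30 log units; that floor lies within the scatter), which gives only a floor for the step, and the steps involving compound 1 and compound 3 cannot be read.

Going by these compounds, whether pyridin-3-yl or piperidin-4-yl on this carbonyl carbon would give a number or a limit stays open. The true value of compound 2 also stays open, and the comparison rests on a single limit: the limit of > 100 ug/mL in this assay, at which 1 of the 4 values shown sits.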